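The source may hold more compounds than are shown below. What is called first, only, known or untested is meant among the compounds shown, and "the series" means these compounds.

Within the data shown here, in an ADME assay on HUVEC cells (Homo sapiens) for inhibition, read by MTT assay, with a stated time of 48 h (on this read-out higher numbers stand for weaker inhibition and lower numbers for stronger inhibition), compound 1 (`Fc1ccc(/C=N/Nc2nc(-c3ccc(F)c(F)c3)cs2)cc1F`) gives 59700 nM, the only true number so far. Compound 2 (`COc1ccccc1-c1csc(N/N=C/c2ccc(F)c(F)c2)n1`) reads > 100000 nM, which is a limit of the assay. Compound 3 (`Fc1ccc(/C=N/Nc2nc(-c3cccc(Br)c3)cs2)cc1F`) reads > 100000 nM, which is also a limit, so compound 3 has no number of its own. The series therefore stands largely at the limit of > 100000 nM in this assay, at which 2 of the 3 values shown sit.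

Compound 4 (`Fc1ccc(/C=N/Nc2nc(-c3ccc(Br)cc3)cs2)cc1F`) keeps the shared core and changes only the aryl group: 4-bromophenyl in place of 3-bromophenyl on an aromatic carbon.

Among the measured compounds shown here, no measured step swaps 3-bromophenyl for 4-bromophenyl. The nearest evidence is an at least 1.6-fold higher number from compound 1 to compound 3 (0.22 log units; that floor lies within the scatter), and an at least 1.6-fold higher number from compound 1 to compound 2 (0.22 log units; that floor lies within the scatter) runs the same way. Both are changes to the same aryl group, and neither floor goes beyond the scatter. Between the two limits there is a step that the two limits leave unreadable from compound 2 to compound 3.

These steps give no direction for the present change, so no step beyond the scatter is expected in this assay. The estimated step is an at least 1.1-fold lower number from compound 3 to compound 4 (0.04 log units; that floor lies within the scatter). A reading that is only a limit remains quite likely. Compound 4 is estimated at 90000 nM, with an expected range of 40000 nM to 200000 nM.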

Compound 4, half-maximal inhibitory concentration: > 100000 nM
Compound 4 gave a limit, no number (the forecaster's own chance of this, stated with the estimate: 50%); middle value at least 1.1-fold (0.04 log units) from the limit.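

Moving the bromine from 3-bromophenyl to 4-bromophenyl, on an aromatic carbon next to the ring nitrogen, brings no true number into this assay: compound 4 reads > 100000 nM, which is a limit of the assay. Among these compounds, the steps joining compound 4 to compound 2 and to compound 3 cannot be read, as both ends of each are limits, and the only readable new step is an at least 1.6-fold higher number from compound 1 to compound 4 (0.22 log units; that floor lies within the scatter). All three aryl groups placed here in place of 3,4-difluorophenyl now end at the same limit, so the series has gained a further limit but no measured size for any change at this position: the limit of > 100000 nM in this assay, at which 3 of the 4 values shown sit.

Among the compounds shown here, whether the place of the bromine on the phenyl ring matters at all stays open, as does whether any of these limits lies truly apart from the single true number of the series. Also open, on these data alone, is whether an amine or a carboxylic acid in place of the bromine on this phenyl ring would give a true number in this assay.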